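Extending the Amide Substituent of Compound 3

The source may hold more compounds than are shown below. What is called first, only, known or untested is meant among the compounds shown, and "the series" means these compounds.

Of the compounds shown here, three built on one shared core have been measured in an ADME assay on microsomes from liver (Mus musculus, strain CD-1) for metabolic stability, read by LC-MS, tested at 2 uM; on this read-out higher numbers stand for a longer-lived compound and lower numbers for a shorter-lived compound. Compound 1 `CN1CCC(CNS(=O)(=O)c2ccccc2Nc2cc(-c3ccc4ccn(C)c4c3)c3nccnc3c2)C1` gives 0.633 h in this assay, and compound 2 `CN1CCC(NS(=O)(=O)c2ccccc2Nc2cc(-c3ccc4ccn(C)c4c3)c3nccnc3c2)C1` gives 0.667 h. Among the compounds with values here, the single step between them, a 1.1-fold higher number from compound 1 to compound 2 (0.02 log units; within the scatter), concerns a sulfonamide nitrogen that compound 3 does not carry. Compound 3 `CNC(=O)c1ccncc1Nc1cc(-c2ccc3ccn(C)c3c2)c2nccnc2c1` gives 0.45 h in this assay, the lowest of the three numbers, yet its gaps to compound 1 and to compound 2 both lie within the scatter, so the three values cannot be told apart on this evidence.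

Compound 4 `CC(=O)N1CCOC(CNC(=O)c2ccncc2Nc2cc(-c3ccc4ccn(C)c4c3)c3nccnc3c2)C1` differs from compound 3 in one place: 4-acetylmorpholin-2-yl in place of hydrogen on a saturated chain carbon bound to an amide-type nitrogen. Within the data shown here, no measured pair alters this part of the molecule. Among the measured compounds shown here, the only step available, from compound 1 to compound 2, changes a different appendage and is itself within the scatter, so it gives no direction for the present change. The step in this assay is therefore expected to be a 1.1-fold higher number from compound 3 to compound 4 (0.05 log units; within the scatter), not beyond the scatter. Compound 4 is estimated to give 0.5 h in this assay, with a range from 0.25 h to 1 h, the width reflecting the absence of any comparable step.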

Compound 4, half-life: 0.217 h
For compound 4 the middle estimate is 2.3-fold (0.36 log units) above the measured one; measured number outside the range, below it.
By their numbers in this assay, from the lowest: compound 4; then compounds 3, 1 and 2 (each within the scatter of the next).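

In this assay, within the data shown here, the change from methyl to (4-acetylmorpholin-2-yl)methyl on the amide-type nitrogen gives a 2.1-fold lower number from compound 3 to compound 4 (0.32 log units; beyond the scatter) and so provides the first step in this set that lies beyond the scatter. The earlier compounds shown here gave no reading at this place, and it now shows that the number can respond to what is attached to the saturated chain carbon bound to that nitrogen, with this one large substituent moving it downward by a modest step. Nothing in the data shown explains this fall in the number.

The compounds shown leave open whether the lower number goes with the acetyl group, with the six-membered non-aromatic ring that carries it, or simply with having any substituent on that carbon. As far as these compounds go, how an ethyl group, a longer chain, a ring bearing a free amine in place of the acetylated nitrogen, or a carboxylic acid at the same place would read in this assay also remains open, as does whether any group there could move the number upward.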